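The source may hold more compounds than are shown below. What is called first, only, known or untested is meant among the compounds shown, and "the series" means these compounds.

Measured compounds:
- compound 1 `COc1ccc(-n2nc(-c3ccccc3)nc2CNc2ccc(C(=O)NO)cc2)cc1` gives 127 nM
- compound 2 `O=C(NO)c1ccc(NCc2nc(-c3cccc(Cl)c3)nn2-c2ccccc2)cc1` gives 115 nM
- compound 3 `COc1ccc(-n2nc(-c3ccc(O)cc3)nc2CNc2ccc(C(=O)NO)cc2)cc1` gives 102 nM

In an assay on Sf9 cells for inhibition of protein deacetylase HDAC6 (Homo sapiens), read by fluorescence, with a stated time of 40 min (a higher number here means a weaker inhibitor, a lower number a stronger inhibitor), compound 1 stands at the highest of the three numbers, but compound 2 and compound 3 lie within the scatter of it, so none of the three can be set apart from the others. For the measured compounds named here, the one single-point step that is known, a 1.2-fold lower number from compound 1 to compound 3 (0.10 log units; within the scatter), concerns hydroxy in place of hydrogen on an aromatic carbon and does not touch the position changed here.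

Compound 4 `O=C(NO)c1ccc(NCc2nc(-c3ccccc3)nn2-c2cccc(Cl)c2)cc1` differs from compound 1 by 3-chlorophenyl in place of 4-methoxyphenyl on an aromatic nitrogen. Going by the values given here, no measured step covers a change at that aromatic nitrogen. Compound 2 carries a 3-chlorophenyl at a different place and its value is close to that of compound 1, which is the only hint the data give that a 3-chlorophenyl is tolerated somewhere on the shared core. With nothing more to go on, the step is expected to be small: a 1.1-fold lower number from compound 1 to compound 4 (0.02 log units; within the scatter) is the estimate, not beyond the scatter in either direction. Compound 4 is therefore expected to give about 120 nM, with a likely range from 50 nM to 300 nM.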

Compound 4, half-maximal inhibitory concentration: 678 nM
Estimate against measurement, compound 4: 5.7-fold (0.75 log units) below; the whole stated range lies below it.
By their numbers in this assay, from the lowest: compounds 3, 2 and 1 (each within the scatter of the next); then compound 4.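

In this assay, the aromatic nitrogen of the shared core turns out to be a place where the choice of group counts: 3-chlorophenyl in place of 4-methoxyphenyl gives a 5.3-fold higher number from compound 1 to compound 4 (0.73 log units; beyond the scatter) (modest, but clear of the scatter). The only earlier single-place step, a 1.2-fold lower number from compound 1 to compound 3 (0.10 log units; within the scatter), made at another position, had shown no change that could be read. Nothing measured here bears on why the number rises at this nitrogen.

The step removes the methoxy group and brings in the chlorine at once, so the compounds shown do not tell which of the two carries the change. Going by these compounds, whether a plain phenyl, a 3-methoxyphenyl or a 4-chlorophenyl on this nitrogen would sit with compound 1 or with compound 4 stays open.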